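A chloro-to-methyl swap on the core of compound 3

The compounds below may be only part of what the source reports. "The series", "measured", "known", "first", "only" and "open" are said of these compounds alone.

Going by the values given here, compound 3 `CCOc1ccc(/C=C2\CN(CC(=O)O)c3c(Cl)cccc3C2=O)cc1` gives the highest of the three numbers so far in an assay on HL-60 cells for inhibition of glutathione S-transferase P (Homo sapiens), read by spectrophotometry, tested at 20 uM (a higher number here means more inhibition at the concentration tested (going by the name of the read-out), a lower number less inhibition), namely 59.1%. Among the compounds with values here, compound 1 `Cc1ccc2c(c1)C(=O)/C(=C/c1ccc(F)cc1)CN2CC(=O)O` gives 16.1% and compound 2 `COc1cccc(/C=C2\CN(CC(=O)O)c3ccc(C)cc3C2=O)c1` gives 14.4%; the one measured step, a number 1.7 percentage points lower from compound 1 to compound 2 (within the scatter), concerns the aryl group on the double-bonded chain carbon and says nothing about the fused ring. Compound 4 `CCOc1ccc(/C=C2\CN(CC(=O)O)c3c(C)cccc3C2=O)cc1` differs from compound 3 by methyl in place of chloro on an aromatic carbon. Within the data shown here, no measured step bears on this change, so the expectation rests on the standing of compound 3 alone, with a modest drop thought more likely than a gain. Compound 4 is therefore expected to show a step of a number 19.1 percentage points lower from compound 3 to compound 4 (beyond the scatter). The estimate for compound 4 is 40%, within 20% to 60%.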

Compound 4, a percentage reported as inhibition, at one concentration (the size of the read-out at that concentration, not a potency): 42.4%
The estimate for compound 4 lay 2.4 percentage points below the measured number; the range from low to high includes it.
By their numbers in this assay, from the lowest: compounds 2 and 1 (each within the scatter of the next); then compound 4; then compound 3.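

In this assay, going by these compounds alone, methyl in place of chloro on this aromatic carbon gives the first measured step on the fused ring of the shared core (a number 16.7 percentage points lower from compound 3 to compound 4 (beyond the scatter)). This shows that the position, ortho to a fused ring and meta to a fused ring, is not indifferent to a change of one heavy atom for another, even though neither group carries hydrogen-bond donors or acceptors. Going by these compounds, whether an amine, a methoxy or a longer chain here would read closer to compound 3 or to compound 4 remains open. No measurement shown explains the step.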